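Amino for chloro on the core of compound 2

The source may hold more compounds than are shown below. What is called first, only, known or untested is meant among the compounds shown, and "the series" means these compounds.

Three compounds of the series share one core and differ at a single aromatic carbon. Compound 1 `Cc1nc(N)nc2c1c(-c1ccc3oc(N)nc3c1)nn2C(C)C` bears a methyl there, and in a physicochemical assay for solubility, read by HPLC, in phosphate buffer, measured as kinetic solubility, with a stated time of 24 h, at 20 degrees C, at pH 7.4, tested at 100 uM (on this read-out lower numbers stand for lower solubility and higher numbers for higher solubility), compound 1 gives 74000 nM. Compound 2 `CC(C)n1nc(-c2ccc3oc(N)nc3c2)c2c(Cl)nc(N)nc21` carries chloro, and in this assay compound 2 gives 2000 nM, the lowest of the three numbers. Compound 3 `CC(C)n1nc(-c2ccc3oc(N)nc3c2)c2c(Br)nc(N)nc21` carries bromo, and in this assay compound 3 gives 4000 nM. The step of a 37-fold lower number from compound 1 to compound 2 (1.57 log units; beyond the scatter) and the step of a 19-fold lower number from compound 1 to compound 3 (1.27 log units; beyond the scatter) are both large and beyond the scatter, whereas the step of a 2.0-fold higher number from compound 2 to compound 3 (0.30 log units; within the scatter) stays within it.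

Compound 4 `CC(C)n1nc(-c2ccc3oc(N)nc3c2)c2c(N)nc(N)nc21` is not yet measured. Relative to compound 2 the change is amino in place of chloro on an aromatic carbon, on the aromatic carbon next to the ring nitrogen and opposite the ring nitrogen. Within the data shown here, no measured step swaps a halogen for an amino group, so the move can only be read against the methyl-to-halogen steps, which run the other way.

Compound 4 is therefore expected to give a number in this assay well above that of compound 2, since the reverse move from methyl to halogen gave a 37-fold lower number from compound 1 to compound 2 (1.57 log units; beyond the scatter). The expected step of a 35-fold higher number from compound 2 to compound 4 (1.54 log units; beyond the scatter) is accordingly large. The estimate for compound 4 is 70000 nM, with a range from 25000 nM to 100000 nM.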

Compound 4, solubility: 88000 nM
Estimate against measurement, compound 4: 1.3-fold (0.10 log units) below, within the range that was stated.
By their numbers in this assay, from the lowest: compounds 2 and 3 (each within the scatter of the next); then compounds 1 and 4 (each within the scatter of the next).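

Amino in place of chloro, on the aromatic carbon next to the ring nitrogen, gives a 44-fold higher number from compound 2 to compound 4 (1.64 log units; beyond the scatter) in this assay and amino in place of bromo gives a 22-fold higher number from compound 3 to compound 4 (1.34 log units; beyond the scatter) on the same read-out, so the large gap between the halogens and methyl at this carbon now also appears between the halogens and a second, different group. Amino in place of methyl gives a 1.2-fold higher number from compound 1 to compound 4 (0.08 log units; within the scatter) and thus leaves the two groups unseparated, which means that at this position the four compounds fall into two sets, chloro and bromo at the low end and methyl and amino at the high end, with none of the four going against that split. No accompanying measurement bears on why the numbers divide this way.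

From the compounds shown here alone, whether the split extends to other small groups at this carbon remains open, since fluoro, hydroxyl and methoxy could each fall with either set. Also open, going by these compounds, is whether a methylamino or dimethylamino group would stay with amino, and whether the halogen-to-amino step keeps its size when the rest of the shared core changes.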